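Notes on the para substituent: trifluoromethyl to methyl

The source may hold more compounds than are shown below. What is called first, only, known or untested is meant among the compounds shown, and "the series" means these compounds.

In an assay on HepG2 cells for agonist activity at nuclear receptor subfamily 1 group I member 3 (Homo sapiens), read by a luciferase reporter, with a stated time of 23 h (a lower number here means that less compound is needed, a higher number that more compound is needed for the effect), compound 3 `FC(F)(F)c1ccc(-c2nc3sccn3c2/C=N/OCc2ccc(Cl)c(Cl)c2)cc1` gives 880 nM, the lowest of the three numbers in hand. Compound 1 `Clc1ccc(CO/N=C/c2c(-c3cccc4ccccc34)nc3sccn23)cc1Cl` gives 940 nM and sits within the scatter of compound 3, so no order between these two can be read. Compound 2 `CC(C)(C)c1ccc(-c2nc3sccn3c2/C=N/OCc2ccc(Cl)c(Cl)c2)cc1` gives 2400 nM; the step of a 2.7-fold lower number from compound 2 to compound 3 (0.44 log units; beyond the scatter) is beyond the scatter, as is a 2.6-fold higher number from compound 1 to compound 2 (0.41 log units; beyond the scatter), whereas a 1.1-fold lower number from compound 1 to compound 3 (0.03 log units; within the scatter) is not.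

Compound 4 `Cc1ccc(-c2nc3sccn3c2/C=N/OCc2ccc(Cl)c(Cl)c2)cc1` differs from compound 3 by methyl in place of trifluoromethyl on an aromatic carbon. Among the measured compounds shown here, no measured pair shows this exact change. The closest measured step on the same aromatic carbon is a 2.7-fold lower number from compound 2 to compound 3 (0.44 log units; beyond the scatter), where one group gave way to another and the number moved by a modest amount. The exchange of the whole aryl group, a 1.1-fold lower number from compound 1 to compound 3 (0.03 log units; within the scatter), stayed within the scatter. So far, changes at this position have shifted the number at most modestly, and the one step that crossed the scatter had an alkyl group on the side with the higher number. For compound 4 a modest rise in the number is therefore expected, a 1.6-fold higher number from compound 3 to compound 4 (0.20 log units; within the scatter), with the possibility of no change beyond the scatter. The estimate for compound 4 in this assay is 1400 nM, with a range from 500 nM to 4000 nM.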

Compound 4, half-maximal effective concentration: 490 nM
Compound 4: middle estimate off by 2.9-fold (0.46 log units), on the high side; the measured number lies below the stated range.
By their numbers in this assay, from the lowest: compounds 4, 3 and 1 (each within the scatter of the next); then compound 2.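

In this assay, methyl in place of trifluoromethyl on this aromatic carbon gives no readable shift (a 1.8-fold lower number from compound 3 to compound 4 (0.25 log units; within the scatter)), and the exchange of naphthalen-1-yl for 4-methylphenyl also stays within the scatter (a 1.9-fold lower number from compound 1 to compound 4 (0.28 log units; within the scatter)). Methyl in place of tert-butyl gives the largest step in the series so far (a 4.9-fold lower number from compound 2 to compound 4 (0.69 log units; beyond the scatter)), which shows that the higher number of compound 2 does not extend to every alkyl group at this place: compound 4 carries an alkyl group yet cannot be separated from compound 3 or compound 1, so among the four compounds only compound 2 stands apart. No measurement in hand accounts for the separation between tert-butyl and methyl.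

On these data alone, whether the number climbs gradually from methyl to tert-butyl or changes abruptly remains open, and ethyl or isopropyl on the same aromatic carbon would address that. As far as these compounds go, it is also open whether a methoxy group, an amine or a carboxylic acid at this place would stay within the scatter of compound 3 and compound 4 or move as far as tert-butyl does.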